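A longer fluorinated chain on the methylated core

A few compounds are considered here, and "the series" means these few. Any claim that something is new, unique, unknown or untested is made for them only; others in the source may bear on it.

Of the compounds shown here, three of this set have been measured in a functional assay on THP-1 cells (Homo sapiens) for cytotoxicity, read by MTT assay, with a stated time of 24 h; on this read-out higher numbers stand for weaker inhibition and lower numbers for stronger inhibition. Compound 1 `O=c1c2c(C(F)(F)F)cc(-c3ccccc3)nc2ncn1Cc1cn(CCC(F)(F)C(F)(F)C(F)(F)C(F)(F)C(F)(F)C(F)(F)C(F)(F)C(F)(F)F)nn1` carries a long fluorinated chain on its triazole and gives 79.1 ug/mL. Compound 2 `CCCCCCCCCCn1cc(Cn2cnc3nc(-c4ccccc4)cc(C(F)(F)F)c3c2=O)nn1` carries a decyl chain in that place and gives 16.9 ug/mL. Compound 3 `Cc1nc2nc(-c3ccccc3)cc(C(F)(F)F)c2c(=O)n1Cc1cn(CCC(F)(F)C(F)(F)C(F)(F)C(F)(F)C(F)(F)C(F)(F)F)nn1` bears a methyl on the shared core together with a shorter fluorinated chain, and for compound 3 the assay reports only a limit, > 200 ug/mL, which is not a number. Compound 3 therefore stands at the limit of > 200 ug/mL in this assay, at which 1 of the 3 values shown sits, at the weak end of the values shown.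

Compound 4 `Cc1nc2nc(-c3ccccc3)cc(C(F)(F)F)c2c(=O)n1Cc1cn(CCC(F)(F)C(F)(F)C(F)(F)C(F)(F)C(F)(F)C(F)(F)C(F)(F)C(F)(F)F)nn1` differs from compound 3 in one place: 1,1,2,2,2-pentafluoroethyl in place of fluoro on a saturated chain carbon bound to two fluorine atoms and a saturated chain carbon. With this change compound 4 carries the same chain as compound 1, now on the methylated core of compound 3. For the measured compounds named here, no measured pair differs in exactly this way, so the size of the step cannot be read from the measured compounds. Compound 1 gives 79.1 ug/mL and compound 2 gives 16.9 ug/mL, but these two differ in more than one place, so they only frame where the non-methylated compounds sit.

The expected step of an at least 1.3-fold lower number from compound 3 to compound 4 (0.12 log units; that floor lies within the scatter) is small, within the scatter. Compound 4 is expected to give about 150 ug/mL, in a range from 50 ug/mL to 300 ug/mL, with a real chance that this assay again reports only a limit.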

Compound 4, half-maximal inhibitory concentration: > 200 ug/mL
Compound 4 gave a limit, no number; the forecaster's own chance of this, stated with the estimate: 50%; middle value at least 1.3-fold (0.12 log units) from the limit.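

Compound 4 gives only a limit in this assay, > 200 ug/mL, and so joins compound 3 at the weak end: the limit of > 200 ug/mL in this assay, at which 2 of the 4 values shown sit.

Compound 3 and compound 4 both stand at limits, so the step from fluoro to 1,1,2,2,2-pentafluoroethyl on that saturated chain carbon cannot be read, and the longer fluorinated chain brings no number into view on the methylated core. For the compounds shown here, what the result does add is the first comparison of the methyl alone: with the chain held the same, methyl in place of hydrogen on an aromatic carbon gives an at least 2.5-fold higher number from compound 1 to compound 4 (0.40 log units; beyond the scatter).

The compounds shown leave open how far compound 3 and compound 4 lie past the limit, and with that whether chain length matters at all once the methyl is present. They also leave open whether a decyl chain on the methylated core would follow the same step, and whether an ethyl group or an amine in place of the methyl on that aromatic carbon would give a readable number.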